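A few compounds are considered here, and "the series" means these few. Any claim that something is new, unique, unknown or untested is made for them only; others in the source may bear on it.

Of the compounds shown here, two built on one shared core have so far been measured in an ADME assay on microsomes from liver (Homo sapiens) for metabolic stability, read by LC-MS, using NADPH, tested at 5 uM; on this read-out higher numbers stand for a longer-lived compound and lower numbers for a shorter-lived compound. Compound 1 `NS(=O)(=O)c1cc(-c2nnc(CN3CCN(c4ccccc4)CC3)o2)c(Cl)cc1SCc1ccccc1` gives 0.33 h in this assay. Compound 2 `CC(C)(O)c1cn(Cc2nnc(-c3cc(S(N)(=O)=O)c(SCc4ccccc4)cc3Cl)o2)nn1` gives 0.23 h in this assay, the lower of the two numbers, though the step of a 1.4-fold lower number from compound 1 to compound 2 (0.16 log units; within the scatter) lies within the scatter, so the two are not separated. Compound 3 `NS(=O)(=O)c1cc(-c2nnc(CNC(=O)c3ccccc3)o2)c(Cl)cc1SCc1ccccc1` is not yet measured. It differs from compound 2 in one place: benzamido in place of 4-(1-hydroxy-1-methylethyl)-1H-1,2,3-triazol-1-yl on a saturated chain carbon bound to an aromatic carbon. Going by the values given here, no measured step makes this particular exchange. Among the compounds with values here, the only known step, a 1.4-fold lower number from compound 1 to compound 2 (0.16 log units; within the scatter), swapped a different group at the same place and stayed within the scatter, which gives no footing for expecting a shift here either. The estimated step of a 1.3-fold higher number from compound 2 to compound 3 (0.12 log units; within the scatter) is therefore expected to stay small. Compound 3 is expected to give about 0.3 h in this assay, with a range from 0.12 h to 0.75 h.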

Compound 3, half-life: 0.187 h
Estimate against measurement, compound 3: 1.6-fold (0.21 log units) above; the range from low to high includes it.
By their numbers in this assay, from the lowest: compounds 3, 2 and 1 (each within the scatter of the next).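

With benzamido as a third group at this place, on a saturated chain carbon bound to an aromatic carbon, the exchange for the 4-(1-hydroxy-1-methylethyl)-1H-1,2,3-triazol-1-yl group gives a 1.2-fold lower number from compound 2 to compound 3 (0.09 log units; within the scatter) in this assay, and the exchange for 4-phenylpiperazin-1-yl gives a 1.8-fold lower number from compound 1 to compound 3 (0.25 log units; within the scatter) in the same test. Three groups with different ring types and different hydrogen-bond acceptor counts therefore give half-lives that cannot be told apart, which a single step between two compounds could not show. Nothing measured here explains this closeness. Whether any group at this place can move the half-life beyond the scatter remains open, since all three groups shown contain a ring. A carboxylic acid or a simple open-chain amine at the same place would put that question to a different kind of group.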